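Changing the aryl group of compound 2

The compounds below may be only part of what the source reports. "The series", "measured", "known", "first", "only" and "open" are said of these compounds alone.

Within the data shown here, in a functional assay (aorta) with Oryctolagus cuniculus as the target (a higher number here means weaker binding, a lower number tighter binding), compound 2 (`Nc1ccc(OCCCN2CCC(C(c3ccc(F)cc3)c3ccc(F)cc3)CC2)cc1`) gives 31.6 nM and holds the higher of the two numbers so far. Compound 3 (`COc1ccccc1OCCCN1CCC(C(c2ccc(F)cc2)c2ccc(F)cc2)CC1`) has 2-methoxyphenyl in place of 4-aminophenyl on an oxygen on a saturated carbon. Among the measured compounds shown here, compound 1 (`CCc1ccc(OCCCN2CCC(C(c3ccc(F)cc3)c3ccc(F)cc3)CC2)c(OC)c1`), which carries 4-ethyl-2-methoxyphenyl instead, gives 2.51 nM and is the only available comparison. Its step of a 13-fold higher number from compound 1 to compound 2 (1.10 log units; beyond the scatter) is large and beyond the scatter. For the measured compounds named here, the entering group resembles the one compound 1 carries, so most of that gap is expected to close, with an expected 6.3-fold lower number from compound 2 to compound 3 (0.80 log units; beyond the scatter) toward tighter binding. Compound 3 is estimated at 5 nM with an expected range (1.6 nM to 16 nM).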

Compound 3, dissociation constant: 2.51 nM
The estimate for compound 3 lay 2.0-fold (0.30 log units) above the measured number, within the range that was stated.
By their numbers in this assay, from the lowest: compounds 1 and 3 (each within the scatter of the next); then compound 2.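

In this assay, 2-methoxyphenyl in place of 4-aminophenyl gives a 13-fold lower number from compound 2 to compound 3 (1.10 log units; beyond the scatter), so an ethyl group on the aryl ring is not needed to reach the number held by compound 1. With hydrogen in place of that ethyl on an aromatic carbon, the two compounds match, with no change at the digits printed from compound 1 to compound 3 (within the scatter). No measurement here explains the large step.

Because the swap replaces the amino group with a methoxy group and also moves the substituent, the two contributions cannot be separated. A plain phenyl, or ethoxy in place of methoxy, would remain to be compared.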